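The source may report more compounds than this note shows. Statements on the series, on what has been measured and on what is new or still open speak of the compounds shown alone.

Of the compounds shown here, three have been tested in an ADME assay on HEK293 cells (Homo sapiens) for cytotoxicity, read by resazurin assay, with a stated time of 48 h; a lower number here means that less compound is tolerated, a higher number that more compound is tolerated. Compound 1, `O=S(=O)(Nc1ccc(-c2nc3ccccc3o2)cc1)c1cccc(F)c1`, reaches only the limit of the assay, giving > 100000 nM. Compound 3, `O=S(=O)(Nc1ccc(-c2nc3ccccc3o2)cc1)c1cccc(C(F)(F)F)c1`, likewise stops at a limit, giving > 100000 nM. Going by the values given here, compound 2, `O=S(=O)(Nc1ccc2oc(-c3ccccc3)nc2c1)c1cccc(F)c1`, is the one compound with a number: in this assay compound 2 gives 68000 nM, and its two companions sit at the limit of > 100000 nM in this assay, at which 2 of the 3 values shown sit. Among the compounds with values here, the single step between measured compounds, from compound 1 to compound 3, is a step that the two limits leave unreadable from compound 1 to compound 3, because the limit of > 100000 nM in this assay, at which 2 of the 3 values shown sit, hides both ends of it; that step is trifluoromethyl in place of fluoro on an aromatic carbon.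

Compound 4, `O=S(=O)(Nc1ccc2oc(-c3ccccc3)nc2c1)c1ccc(Cl)c(Cl)c1`, is not yet measured. It differs from compound 2 by 3,4-dichlorophenyl in place of 3-fluorophenyl on a sulfonyl sulfur. Within the data shown here, no measured step offers a readable guide here: the only comparison available, from compound 1 to compound 3, is also a change of the substituent on the ring that hangs from the sulfonyl sulfur, yet its size cannot be read. Without a readable precedent, no step beyond the usual scatter is expected in this assay, in either direction, although the chance that compound 4 also ends at a limit is real. The expected step amounts to a 1.2-fold lower number from compound 2 to compound 4 (0.09 log units; within the scatter). Compound 4 is therefore estimated at 55000 nM, within a range from 15000 nM to 150000 nM.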

Compound 4, half-maximal cytotoxic concentration: 71000 nM
Compound 4: the middle estimate sits 1.3-fold (0.11 log units) below what was measured; low and high end bracket the measured number.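

In this assay, the ring on the sulfonyl sulfur now has a step that can be read, and it is a 1.0-fold higher number from compound 2 to compound 4 (0.02 log units; within the scatter). On the core of compound 2, then, 3,4-dichlorophenyl can take the place of 3-fluorophenyl, with two chlorines instead of one fluorine and the heavy-atom count going from 7 to 8, and the number stays within the usual scatter. The earlier change on this same ring, from compound 1 to compound 3, gave no such information, and it still cannot be read because both of its ends are limits and not numbers: the limit of > 100000 nM in this assay, at which 2 of the 4 values shown sit.

The compounds shown leave open whether this tolerance at the sulfonyl sulfur extends to very different groups, such as a phenyl ring carrying a carboxylic acid or an amine, or a longer alkyl chain in place of the ring. They also leave open whether the same swap would behave alike on the core of compound 1, since a single step on one core says nothing about another.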